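Swapping 4-ethylphenyl for thiophen-3-yl on the shared core

This account rests on a few compounds, and the source may have more. Where it says the series, first, only, none or still open, it means among the compounds named here.

In a functional assay on A549 cells (Homo sapiens) for inhibition, read by MTT assay, with a stated time of 48 h (on this read-out higher numbers stand for weaker inhibition and lower numbers for stronger inhibition), compound 1 `CCc1ccc(-c2nc3ccccn3c2Sc2ccccc2)cc1` gives 56200 nM. That number lies within the scatter of compound 2 `Clc1ccc(Sc2c(-c3cccs3)nc3ccccn23)cc1`, which gives 69800 nM. Compound 3 `Clc1ccc(Sc2c(-c3ccccc3)nc3ccccn23)cc1` gives a lower number, 27700 nM, and its gap to compound 1 lies beyond the scatter. Compound 1 thus shares the high end of this small set with compound 2, on the weaker side of the read-out.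

Compound 4 `c1ccc(Sc2c(-c3ccsc3)nc3ccccn23)cc1` has not yet been measured. It keeps the phenylsulfanyl group of compound 1 but carries thiophen-3-yl in place of 4-ethylphenyl on an aromatic carbon, next to the ring atom that bears that group: thiophen-3-yl in place of 4-ethylphenyl on an aromatic carbon.

Within the data shown here, only one measured step bears on this change. Phenyl in place of thiophen-2-yl gave a 2.5-fold lower number from compound 2 to compound 3 (0.40 log units; beyond the scatter), a modest step. Read in reverse, it hints at a somewhat higher number for a thiophene-bearing compound. However, it concerns thiophen-2-yl rather than thiophen-3-yl, and no measured step covers 4-ethylphenyl, so the guidance is weak. No shift beyond the scatter is therefore expected.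

The expected change is a 1.1-fold higher number from compound 1 to compound 4 (0.03 log units; within the scatter). For compound 4 the estimated value is 60000 nM, with an expected range of 25000 nM to 140000 nM.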

Compound 4, half-maximal inhibitory concentration: 72900 nM
The estimate for compound 4 lay 1.2-fold (0.08 log units) below the measured number; the measured number falls inside the stated range.
By their numbers in this assay, from the lowest: compound 3; then compounds 1, 2 and 4 (each within the scatter of the next).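

In this assay, the swap on this aromatic carbon gives a 1.3-fold higher number from compound 1 to compound 4 (0.11 log units; within the scatter), so with the phenylsulfanyl group held constant, the two groups cannot be told apart at this position. Among these compounds, the exchange replaces 4-ethylphenyl, with 8 heavy atoms and a six-membered aromatic ring of carbon only, with thiophen-3-yl, with 5 heavy atoms and a five-membered aromatic ring with 1 hetero atom, and this larger difference in make-up leaves the number within the scatter, whereas the only earlier step at this carbon, a 2.5-fold lower number from compound 2 to compound 3 (0.40 log units; beyond the scatter), was a different exchange and lay beyond it. Nothing available explains why this exchange leaves the number within the scatter.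

The compounds shown leave open whether a group of another kind on this aromatic carbon, such as an aminomethyl group or a carboxylic acid, would move the number beyond the scatter. They also leave open whether a chain longer than ethyl, such as butyl, in place of the ethyl of 4-ethylphenyl would change the number of compound 1.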